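The compounds below may be only part of what the source reports. "The series", "measured", "known", "first", "only" and "open" are said of these compounds alone.

Compound 1 `O=C(CN1CCN(c2nnc(Cc3ccccc3)c3ccccc23)CC1)Nc1c(F)cccc1F`: 84500 nM
Compound 2 `Cc1ccc(F)cc1NC(=O)CN1CCN(c2nnc(Cc3ccncc3)c3ccccc23)CC1`: 38900 nM

In a functional assay on A549 cells (Homo sapiens) for cytotoxicity, read by MTT assay, with a stated time of 72 h (a lower number here means a stronger inhibitor, a higher number a weaker inhibitor), compound 2 gives the lower of the two numbers, 38900 nM, and the gap to compound 1 lies beyond the scatter. Compound 3 `O=C(CN1CCN(c2nnc(Cc3ccncc3)c3ccccc23)CC1)Nc1c(F)cccc1F` differs from compound 2 by one change, with 2,6-difluorophenyl in place of 5-fluoro-2-methylphenyl on an amide-type nitrogen. The incoming group also sits on compound 1, which gives 84500 nM, but that compound differs from compound 3 elsewhere. A small rise is therefore expected, and the estimated step of a 1.4-fold higher number from compound 2 to compound 3 (0.15 log units; within the scatter) stays within the scatter. For compound 3 the expected value is 55000 nM, with an estimated range of 22000 nM to 120000 nM.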

Compound 3, half-maximal inhibitory concentration: 54400 nM
Beside the measured number, compound 3's estimate is 1.0-fold (0.00 log units) above it; low and high end bracket the measured number.
By their numbers in this assay, from the lowest: compounds 2, 3 and 1 (each within the scatter of the next, the first and the last beyond it).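

In this assay, exchanging 5-fluoro-2-methylphenyl for 2,6-difluorophenyl on the amide-type nitrogen, with pyridin-4-yl held fixed, gives a 1.4-fold higher number from compound 2 to compound 3 (0.15 log units; within the scatter), so these two rings cannot be told apart at this position. With 2,6-difluorophenyl held fixed, pyridin-4-yl in place of phenyl on the saturated chain carbon gives a 1.6-fold lower number from compound 1 to compound 3 (0.19 log units; within the scatter), so neither single change separates its pair. Nothing available here explains these numbers. As far as these compounds go, whether a group other than a substituted phenyl on the amide-type nitrogen, such as a cyclohexyl ring or a longer alkyl chain, would shift the number beyond the scatter remains open.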